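Acid dissociation in the series: step from compound 2 to compound 3

The compounds below may be only part of what the source reports. "The series", "measured", "known", "first", "only" and "open" are said of these compounds alone.

Measured so far in a physicochemical assay for acid dissociation:
compound 1, `COc1ccc(-c2c(C)nc3c(NCc4ccc(C(N)=O)cc4)cc(C)cn23)cc1OC`, gives 6.6
compound 2, `COc1ccc(-c2c(C)nc3c(NCc4cccnc4)cc(C)cn23)cc1OC`, gives 6.5

Compound 2 holds the lower of the two numbers, and its neighbour compound 1 sits only a number 0.10 log units lower from compound 1 to compound 2 (within the scatter) away. Compound 3, `COc1ccc(-c2c(C)nc3c(NCC4CCOCC4)cc(C)cn23)cc1OC`, differs from compound 2 by oxan-4-yl in place of pyridin-3-yl on a saturated chain carbon bound to a nitrogen on an aromatic ring. Within the data shown here, the one step at this position, from compound 1 to compound 2, stayed within the scatter; the step to compound 3 is therefore also expected to be small, with no clear direction beyond the scatter. For compound 3 the estimate in this assay is 6.7, between 6.3 and 7.1, meaning an expected step of a number 0.20 log units higher from compound 2 to compound 3 (within the scatter).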

Compound 3, acid dissociation constant: 6.7
For compound 3 middle estimate and measured number coincide at the digits printed, and the stated range covers the measured number.
By their numbers in this assay, from the lowest: compounds 2, 1 and 3 (each within the scatter of the next).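

In this assay, oxan-4-yl in place of pyridin-3-yl gives a number 0.20 log units higher from compound 2 to compound 3 (within the scatter), and oxan-4-yl in place of 4-carbamoylphenyl gives a number 0.10 log units higher from compound 1 to compound 3 (within the scatter). At this position, on a saturated chain carbon bound to a nitrogen on an aromatic ring, a six-membered non-aromatic ring therefore leaves the number within the scatter of both aromatic rings. No supporting data bear on this result. On these data alone, whether a piperidin-4-yl amine, a carboxylic acid or a longer chain at the same place would give a step beyond the scatter remains open.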